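The source may hold more compounds than are shown below. What is called first, only, known or untested is meant among the compounds shown, and "the series" means these compounds.

Within the data shown here, compound 1 `O=C1c2c[n+]([O-])c3ccccc3c2C(=O)c2c1c1ccccc1n2Cc1cn(CC(O)CO)nn1` is one of two compounds measured in a toxicity assay on L02 cells (Homo sapiens) for cytotoxicity, read by MTT assay, with a stated time of 72 h; a higher number here means a weaker inhibitor, a lower number a stronger inhibitor. In this assay compound 1 gives 1070 nM, the higher of the two numbers. Among the measured compounds shown here, its only neighbour, compound 2 `CC1(C)OC[C@H](Cn2cc(Cn3c4c(c5ccccc53)C(=O)c3c[n+]([O-])c5ccccc5c3C4=O)nn2)O1`, gives 470 nM in this assay; the step of a 2.3-fold lower number from compound 1 to compound 2 (0.36 log units; beyond the scatter) puts 2,2-dimethyl-1,3-dioxolan-4-yl in place of 1,2-dihydroxyethyl on a saturated chain carbon bound to an aromatic nitrogen. Compound 3 `CN1CCN(CCCCCCn2c3c(c4ccccc42)C(=O)c2c[n+]([O-])c4ccccc4c2C3=O)CC1` has not yet been measured. It differs from compound 1 thus: 5-(4-methylpiperazin-1-yl)pentyl in place of 1-(2,3-dihydroxypropyl)-1H-1,2,3-triazol-4-yl on a saturated chain carbon bound to an aromatic nitrogen. For the measured compounds named here, no measured step covers a change of this kind; the one step known alters only the end of the side chain while the triazole stays, so it is a weak guide, showing at most a modest shift for changes on this chain. The number for compound 3 is therefore expected close to that of compound 1, as a 1.5-fold lower number from compound 1 to compound 3 (0.18 log units; within the scatter), with no direction assured beyond the scatter. The estimate for compound 3 is 700 nM, between 200 nM and 2500 nM.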

Compound 3, half-maximal inhibitory concentration: 3800 nM
Beside the measured number, compound 3's estimate is 5.4-fold (0.73 log units) below it; the whole stated range lies below it.
By their numbers in this assay, from the lowest: compound 2; then compound 1; then compound 3.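

At this place, on a saturated chain carbon bound to an aromatic nitrogen, the side group can push the number in this assay upward as well as downward: the new change gives a 3.6-fold higher number from compound 1 to compound 3 (0.55 log units; beyond the scatter), whereas the earlier one gave a 2.3-fold lower number from compound 1 to compound 2 (0.36 log units; beyond the scatter). Compound 3 is also the first compound shown without the triazole ring, so its number shows what happens when the whole group is exchanged, not just the end of the side chain. No measurement shown gives a reason for this rise.

On these data alone, the exchange alters the triazole ring, the chain and the end group all at once, so how much each contributes stays open. A morpholine in place of the 4-methylpiperazine on the same pentyl chain, or a shorter chain carrying the same 4-methylpiperazine, would help to separate these parts.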